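Ethylsulfonyl in place of allyl: cytotoxicity outlook

The source may hold more compounds than are shown below. What is called first, only, known or untested is meant among the compounds shown, and "the series" means these compounds.

Compound 3 `C=CCN(c1ccnc(Nc2ccc(C#N)cc2)n1)c1c(F)cc(-c2ccc(C#N)cc2)cc1F` sits at the top of the two plain numbers in an ADME assay on MT4 cells (Homo sapiens) for cytotoxicity, read by MTT assay, with a stated time of 5 days (on this read-out lower numbers stand for higher toxicity in this test and higher numbers for lower toxicity in this test), where compound 3 gives 249000 nM. Its nearest neighbour is compound 1 `CCN(c1ccnc(Nc2ccc(C#N)cc2)n1)c1c(F)cc(-c2ccc(C#N)cc2)cc1F`, which in this assay gives 105000 nM, and the move a 2.4-fold higher number from compound 1 to compound 3 (0.38 log units; beyond the scatter). Compound 2 `N#Cc1ccc(Nc2nccc(N(CCCCl)c3c(F)cc(-c4ccc(C#N)cc4)cc3F)n2)cc1` yields only a limit in this assay, namely > 250000 nM; this is the limit of > 250000 nM in this assay, at which 1 of the 3 values shown sits. The move an at least 2.3-fold higher number from compound 1 to compound 2 (0.37 log units; beyond the scatter), while the move a number no higher from compound 2 to compound 3 (the limit leaves the size open).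

Compound 4 `CCS(=O)(=O)N(c1ccnc(Nc2ccc(C#N)cc2)n1)c1c(F)cc(-c2ccc(C#N)cc2)cc1F` differs from compound 3 by ethylsulfonyl in place of allyl on a nitrogen on an aromatic ring. Among the compounds with values here, none of the measured steps touches the same kind of change: they swap one saturated chain substituent for another on the same nitrogen, and each of the two readable steps was modest at best. Carrying that over, the step of a 1.2-fold lower number from compound 3 to compound 4 (0.10 log units; within the scatter) is expected to stay small, probably within the scatter, with a possible drift toward the limit already reached by compound 2. Compound 4 is therefore estimated at 200000 nM in this assay, with a range from 80000 nM to 250000 nM.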

Compound 4, half-maximal cytotoxic concentration: > 125000 nM
Compound 4: a limit, no number (the forecaster's own chance of this, stated with the estimate: 40%); the middle value lies beyond the limit too.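

In this assay compound 4 gives a limit, not a number: the limit of > 125000 nM in this assay, at which 1 of the 4 values shown sits. Within the data shown here, this is the only group in the set that puts sulfur and 2 hydrogen-bond acceptors on the nitrogen on an aromatic ring, and the only readable step is an at least 1.1-fold higher number from compound 1 to compound 4 (0.07 log units; that floor lies within the scatter), so ethylsulfonyl is not separated from ethyl at this position. The steps to compound 4 from compound 3 and from compound 2 cannot be read, which leaves ethylsulfonyl unplaced against allyl and 3-chloropropyl, and the change adds only a second limit to the series, alongside that of compound 2.

The compounds shown leave open whether a longer sulfonyl chain such as butylsulfonyl on this nitrogen would also end in a limit or would give a plain number in this assay. They also leave open how an aminoethyl chain or a carboxylic acid on a short chain at the same nitrogen would read against compound 1, which gives 105000 nM, and against compound 3, which gives 249000 nM.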